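Chloro to Methyl: A Small Swap in HeLa Growth Inhibition

A few compounds are considered here, and "the series" means these few. Any claim that something is new, unique, unknown or untested is made for them only; others in the source may bear on it.

Compound 1 `Nc1ccccc1NC(=O)/C=C/c1ccc(CSc2ccc(Cl)cc2)cc1`: 1.94%
Compound 2 `CCc1ccc(SCc2ccc(C(=O)Nc3ccccc3N)cc2)cc1`: 30.8%

Of the compounds shown here, two have been measured in a functional assay on HeLa cells (Homo sapiens) for inhibition, read by CCK-8 assay, with a stated time of 72 h, tested at 2 uM (on this read-out lower numbers stand for less inhibition of growth and higher numbers for more inhibition of growth at the one concentration tested), so far. Compound 1 gives 1.94%, the lower of the two values. Compound 2 gives 30.8%, and the gap between the pair lies beyond the usual scatter. Compound 1 therefore starts at the bottom of this small set, with very little growth inhibition at the one concentration tested.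

The next compound to be measured is compound 3 `Cc1ccc(SCc2ccc(/C=C/C(=O)Nc3ccccc3N)cc2)cc1`. It differs from compound 1 at a single place: methyl in place of chloro on an aromatic carbon. The swap turns 4-chlorophenyl into 4-methylphenyl, and the rest of the structure is unchanged.

For the measured compounds named here, no measured pair shows this swap, so the data give no direct guide to its size. Only a small upward move, not beyond the scatter, is expected: a number 4.1 percentage points higher from compound 1 to compound 3 (within the scatter). The estimated value for compound 3 is 6%, with an expected range from 0% to 22%.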

Compound 3, percent growth inhibition at one concentration: 25.5%
Estimate against measurement, compound 3: 19.5 percentage points below; measured number above the stated range.
By their numbers in this assay, from the lowest: compound 1; then compounds 3 and 2 (each within the scatter of the next).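

The result shows that the aromatic carbon para to a large group is not a silent place in this series: in this assay, a number 23.6 percentage points higher from compound 1 to compound 3 (beyond the scatter), so a 4-methylphenyl in place of a 4-chlorophenyl moves growth inhibition beyond the scatter. For the compounds shown here, this is the first direct reading of the swap, which no earlier pair held. Chloro and methyl count the same under the listed terms, each with one heavy atom, no ring, no hydrogen-bond donors or acceptors and no net charge, so those counts do not separate the two compounds, and nothing measured on them accounts for the step.

On these data alone, it remains open whether this rise is particular to methyl or would also appear with another group on the same carbon, such as an amine, a methoxy group or a carboxylic acid. As far as these compounds go, it is equally open whether the step would keep its size at other concentrations, as each number here is a single reading at the one concentration tested, and whether it would carry over to a different part of the series.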